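Pyridin-4-yl for Methoxy and Microsomal Clearance

The compounds below may be only part of what the source reports. "The series", "measured", "known", "first", "only" and "open" are said of these compounds alone.

compound 1 `COc1cc(C(O)(C(F)(F)F)C(F)(F)F)cnc1N1CCN(S(=O)(=O)c2ccc(N)nc2)CC1`: < 14 mL.min-1.g-1
compound 2 `CC(C)(O)C#Cc1cc(C(O)(C(F)(F)F)C(F)(F)F)cnc1N1CCN(S(=O)(=O)c2ccc(N)nc2)CC1`: < 14 mL.min-1.g-1

In an ADME assay (liver) for metabolic stability, with Liver microsome (Homo sapiens) as the target, using microsomes and NADPH, with a stated time of 30 min, tested at 1 uM (on this read-out lower numbers stand for slow clearance and higher numbers for fast clearance), compound 1 gives < 14 mL.min-1.g-1, which is a limit of the assay rather than a number. Compound 2 gives < 14 mL.min-1.g-1, also a limit. The step from compound 1 to compound 2, a step that the two limits leave unreadable from compound 1 to compound 2, has a size that cannot be read from two limits. Both results share (the limit of < 14 mL.min-1.g-1 in this assay, at which 2 of the 2 values shown sit).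

Compound 3 `Nc1ccc(S(=O)(=O)N2CCN(c3ncc(C(O)(C(F)(F)F)C(F)(F)F)cc3-c3ccncc3)CC2)cn1` differs from compound 1 by pyridin-4-yl in place of methoxy on an aromatic carbon. For the measured compounds named here, the only measured step, a step that the two limits leave unreadable from compound 1 to compound 2, is the one change at this same aromatic carbon, yet its size stays unreadable, so no direction beyond the usual scatter can be expected from it. With both measured compounds sitting at the limit, compound 3 is estimated to give 12 mL.min-1.g-1, with a range from 5 mL.min-1.g-1 to 30 mL.min-1.g-1. For compound 3 this estimate means an expected step that the limit leaves unreadable from compound 1 to compound 3.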

Compound 3, intrinsic clearance in microsomes: 15 mL.min-1.g-1
Compound 3: the middle estimate sits 1.3-fold (0.10 log units) below what was measured; the measured number falls inside the stated range.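

For the compounds shown here, with pyridin-4-yl on this aromatic carbon, compound 3 gives 15 mL.min-1.g-1 in this assay, the first value at this position that is a number and not a limit. The change from methoxy is an at least 1.0-fold higher number from compound 1 to compound 3 (0.02 log units; that floor lies within the scatter), and the change from 3-hydroxy-3-methylbut-1-yn-1-yl is an at least 1.0-fold higher number from compound 2 to compound 3 (0.02 log units; that floor lies within the scatter). These are only floors, so an aromatic ring can stand on this carbon with no step shown beyond the usual scatter, although the true size of either step may be larger.

The steps that start from a limit, and the one between the two limits, still cannot be read exactly. Going by these compounds, whether an amine, a carboxylic acid or a saturated ring such as piperidin-4-yl on this carbon would give a clearly different number stays open.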